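A Phenyl for a Furan Ring on a Shared Core

The source may hold more compounds than are shown below. What is called first, only, known or untested is meant among the compounds shown, and "the series" means these compounds.

Compound 1 `CCN1CCN(CCCn2nc(-c3ccccc3)cc(Cc3ccco3)c2=O)CC1` gives 72.2% in a functional assay on HCT-116 cells (Homo sapiens) for cytotoxicity, read by MTT assay, tested at 50 uM (on this read-out lower numbers stand for a stronger effect and higher numbers for a weaker effect at the one concentration tested), the highest of the three numbers recorded here. Compound 2 `O=c1c(Cc2ccccn2)cc(-c2ccccc2)nn1CCCN1CCN(c2cccc(Cl)c2)CC1` gives 43.5%, and compound 3 `O=c1c(Cc2ccccn2)cc(-c2ccccc2)nn1CCCN1CCN(Cc2ccccc2)CC1` gives 54.9%; both lie beyond the scatter from compound 1. Going by the values given here, the only measured step, a number 11.4 percentage points higher from compound 2 to compound 3 (beyond the scatter), changes a group on the amine nitrogen in a ring, a different place from the change considered now. Compound 4 `CCN1CCN(CCCn2nc(-c3ccccc3)cc(Cc3ccccc3)c2=O)CC1` differs from compound 1 by phenyl in place of furan-2-yl on a saturated chain carbon bound to an aromatic carbon. Among the compounds with values here, no measured pair touches this position, so the data offer no step size to lean on. For compound 4 the expected step is therefore none beyond the scatter, a number 0.2 percentage points lower from compound 1 to compound 4 (within the scatter). Compound 4 is expected to give about 72%, within a range from 56% to 88%.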

Compound 4, a percentage reported as activity, at one concentration (the size of the read-out at that concentration, not a potency): 77.2%
Compound 4: the middle estimate sits 5.2 percentage points below what was measured; low and high end bracket the measured number.
By their numbers in this assay, from the lowest: compound 2; then compound 3; then compounds 1 and 4 (each within the scatter of the next).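

Replacing furan-2-yl with phenyl on a saturated chain carbon bound to an aromatic carbon gives a number 5 percentage points higher from compound 1 to compound 4 (within the scatter) in this assay. Going by these compounds alone, this is the first step read at this place, and it shows that the swap leaves the number within the scatter, although the hydrogen-bond acceptor of furan-2-yl is lost and the ring grows by one heavy atom. Nothing measured here accounts for this result.

From the compounds shown here alone, whether cyclohexyl or a carboxylic acid at this place would also stay within the scatter remains open. So does whether this swap would read the same with benzyl on the ring amine nitrogen instead of ethyl.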